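Methoxy in place of fluoro: working notes

The source may hold more compounds than are shown below. What is called first, only, known or untested is meant among the compounds shown, and "the series" means these compounds.

In a functional assay on HeLa cells (Homo sapiens) for antiproliferative activity, read by cell counting, with a stated time of 2 days (a higher number here means a weaker inhibitor, a lower number a stronger inhibitor), compound 1 (`COc1cc(C(=O)c2sc(Nc3ccc(F)cc3)nc2N)cc(OC)c1OC`) gives 440 nM and compound 2 (`COc1ccccc1C(=O)c1sc(Nc2ccccc2)nc1N`) gives 1200 nM, so compound 1 holds the lower of the two numbers, with a gap beyond the scatter. These two compounds differ in more than one place, so the gap cannot be assigned to any single group.

Compound 3 (`COc1ccc(Nc2nc(N)c(C(=O)c3cc(OC)c(OC)c(OC)c3)s2)cc1`) keeps the core of compound 1 and changes one group: methoxy in place of fluoro on an aromatic carbon. This is methoxy in place of fluoro on an aromatic carbon, para to a large group, which turns 4-fluorophenyl into 4-methoxyphenyl.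

Among the measured compounds shown here, no measured pair isolates this exchange, so the data give no direct size for it. In this assay no change beyond the scatter is expected, and no firm direction can be assigned. The expected step, a 1.1-fold lower number from compound 1 to compound 3 (0.04 log units; within the scatter), is therefore small. For compound 3 the estimated value is 400 nM, with an expected range of 130 nM to 1200 nM.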

Compound 3, half-maximal inhibitory concentration: 560 nM
Beside the measured number, compound 3's estimate is 1.4-fold (0.15 log units) below it; measured number inside the range.
By their numbers in this assay, from the lowest: compounds 1 and 3 (each within the scatter of the next); then compound 2.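

In this assay, among the compounds shown here, the exchange of fluoro for methoxy on an aromatic carbon, para to a large group, now has a measured size: a 1.3-fold higher number from compound 1 to compound 3 (0.10 log units; within the scatter) is the first step that isolates a single change, since the earlier pair differed in more than one place. At this position 4-fluorophenyl and 4-methoxyphenyl cannot be separated in this assay, so in this pair the methoxy group, with its additional heavy atom and hydrogen-bond acceptor, brings no step beyond the scatter. No measurement available here bears on why the two groups read alike.

The compounds shown leave open whether this position stays as undemanding with an amine, a carboxylic acid or a longer chain such as butoxy in the same place, since fluoro and methoxy are the only two groups compared on this core. They also leave open whether the step seen on the core of compound 1 would carry over to the core of compound 2, as it rests on a single pair.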